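A few compounds are considered here, and "the series" means these few. Any claim that something is new, unique, unknown or untested is made for them only; others in the source may bear on it.

Measured so far:
Compound 1 `COc1cc2c(/C=C3/C(=O)Nc4ccc(Cl)cc43)c(Cl)n(Cc3cc(OC)c(OC)c(OC)c3)c2cc1C` gives 2290 nM in a functional assay on cells (Melanoma cell, Homo sapiens) for cytotoxicity, with a stated time of 48 h; a higher number here means a weaker inhibitor of growth, a lower number a stronger inhibitor of growth.
Compound 2 `COc1ccc2c(c1)/C(=C\c1c(Cl)n(Cc3cc(OC)c(OC)c(OC)c3)c3cc(C)c(OC)cc13)C(=O)N2` gives 14800 nM in this assay.
Compound 3 `COc1c(/C=C2/C(=O)Nc3ccc(Cl)cc32)c2ccccc2n1-c1ccccc1` gives 5620 nM in this assay.

Compound 2 differs from compound 1 by one change, (methoxy in place of chloro on an aromatic carbon). That change gave a 6.5-fold higher number from compound 1 to compound 2 (0.81 log units; beyond the scatter). Compound 4 `COc1ccc2c(c1)/C(=C\c1c(OC)n(-c3ccccc3)c3ccccc13)C(=O)N2` is not yet measured; it differs from compound 3 by the same change, (methoxy in place of chloro on an aromatic carbon), at the same place. The difference between the core of compound 1 and the core of compound 3 is not broken down here; the two values show compound 3 above compound 1 and below compound 2 in this assay.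

Among the compounds with values here, with only one prior instance of the change, the step from compound 3 to compound 4 is expected to be similar, a 5.3-fold higher number from compound 3 to compound 4 (0.73 log units; beyond the scatter), resting on a 6.5-fold higher number from compound 1 to compound 2 (0.81 log units; beyond the scatter). Compound 4 is therefore estimated at 30000 nM, within 10000 nM to 80000 nM.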

Compound 4, concentration for 50% growth inhibition: 2400 nM
The estimate for compound 4 lay 13-fold (1.10 log units) above the measured number; measured number outside the range, below it.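

In this assay, methoxy in place of chloro on an aromatic carbon gave a 2.3-fold lower number from compound 3 to compound 4 (0.37 log units; beyond the scatter), while the same change on the other core gave a 6.5-fold higher number from compound 1 to compound 2 (0.81 log units; beyond the scatter). The effect of this change therefore did not carry from one core to the other, in either direction or size: the same change on two cores in this assay, a 6.5-fold higher number (0.81 log units; beyond the scatter) from compound 1 to compound 2 and a 2.3-fold lower number (0.37 log units; beyond the scatter) from compound 3 to compound 4, 15-fold (1.18 log units) apart, beyond the scatter of two such steps This shows that the core matters for the outcome of the change, but two pairs do not show which difference between the cores matters, nor do they predict the step on a further core.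

Still open, on these data alone, is how an amine or a carboxylic acid at this place would compare with chloro and methoxy on either core. Within the data shown here, also open is whether a core differing from that of compound 1 in one place only would keep the direction seen from compound 1 to compound 2 or the one seen from compound 3 to compound 4.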